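This account rests on a few compounds, and the source may have more. Where it says the series, first, only, none or still open, it means among the compounds named here.

Measured compounds in the series:
compound 1, `CC(=O)N(C)c1ccc2[nH]c(-c3n[nH]c4ccccc34)cc2n1`, 23400 nM
compound 2, `CCC(=O)N(C)c1ccc2[nH]c(-c3n[nH]c4ccccc34)cc2n1`, 33500 nM

Both were run in a functional assay on SMMC-7721 cells (Homo sapiens) for antiproliferative activity, read by MTT assay, with a stated time of 72 h; on this read-out lower numbers stand for stronger inhibition and higher numbers for weaker inhibition. Compound 2 stands at the higher of the two numbers; its nearest neighbour is compound 1, and the step of a 1.4-fold higher number from compound 1 to compound 2 (0.16 log units; within the scatter) is the only one measured so far, so the two compounds cannot be separated on these data.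

The next compound is compound 3, `CN(C(=O)C(C)(C)C)c1ccc2[nH]c(-c3n[nH]c4ccccc34)cc2n1`, not yet measured in this assay. The change from compound 2 is tert-butyl in place of ethyl on a carbonyl carbon. Going by the values given here, the one measured step that bears on it, a 1.4-fold higher number from compound 1 to compound 2 (0.16 log units; within the scatter), is the same kind of growth on the same chain, one carbon shorter, and it stayed within the scatter. Nothing in the measured data points to a step beyond the scatter for compound 3 in this assay; if anything, the direction of the earlier step suggests a slightly higher number rather than a lower one.

Compound 3 is therefore estimated at 45000 nM in this assay, with a range from 18000 nM to 110000 nM, which means an expected step of a 1.3-fold higher number from compound 2 to compound 3 (0.13 log units; within the scatter).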

Compound 3, half-maximal inhibitory concentration: 22200 nM
Estimate against measurement, compound 3: 2.0-fold (0.31 log units) above; measured number inside the range.
By their numbers in this assay, from the lowest: compounds 3, 1 and 2 (each within the scatter of the next).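

In this assay, tert-butyl in place of ethyl on the carbonyl carbon gives a 1.5-fold lower number from compound 2 to compound 3 (0.18 log units; within the scatter) and tert-butyl in place of methyl gives a 1.1-fold lower number from compound 1 to compound 3 (0.02 log units; within the scatter), so even the larger change at this position, from methyl to tert-butyl, stays within the scatter. The earlier step, a 1.4-fold higher number from compound 1 to compound 2 (0.16 log units; within the scatter), therefore does not begin a trend with the size of this group: with methyl, ethyl or tert-butyl on the carbonyl carbon, the three compounds cannot be separated on these data. No information is available to explain why these changes leave the read-out within the scatter.

Going by these compounds, all three groups on the carbonyl carbon are plain carbon groups, so it remains open whether an amine, a carboxylic acid or a phenyl ring in place of tert-butyl would produce a step beyond the scatter. Also open, on these data alone, is the part played by the methyl on the amide-type nitrogen and by the shared core, since both are the same in all three compounds.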